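This account rests on a few compounds, and the source may have more. Where it says the series, first, only, none or still open, it means among the compounds named here.

Measured in a functional assay on U-937 cells (Homo sapiens) for antiproliferative activity, read by MTT assay; on this read-out lower numbers stand for stronger inhibition and higher numbers for weaker inhibition:
- Compound 1, `C#CCN(c1nc2ccc(F)cc2s1)c1nc2ccc(OC)cc2s1`, gives 24900 nM.
- Compound 2, `COc1ccc(-c2cc(CN(c3nc4ccc(F)cc4s3)c3nc4ccc(OC)cc4s3)on2)cc1`, gives 138000 nM.
- Compound 3, `FC(F)(F)Sc1ccc(-c2cc(CN(c3ncccn3)c3nc4ccccc4s3)on2)cc1`, gives 19400 nM.

Compound 3 and compound 1 give numbers that lie within the usual scatter of each other, whereas compound 2 lies beyond that scatter with the clearly higher number. Compound 4, `COc1ccc(-c2cc(CN(c3ncccn3)c3nc4ccccc4s3)on2)cc1`, has not yet been measured. It differs from compound 3 in one spot: methoxy in place of (trifluoromethyl)sulfanyl on an aromatic carbon. For the measured compounds named here, no measured pair shows this exact change, so the expectation rests only on the three numbers above, in which the sole methoxyphenyl compound, compound 2, gives the weakest reading. A shift toward a higher number, of modest size, is therefore expected for the step of a 2.3-fold higher number from compound 3 to compound 4 (0.37 log units; beyond the scatter). Compound 4 is estimated at 45000 nM, with a range from 15000 nM to 150000 nM.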

Compound 4, half-maximal inhibitory concentration: 13900 nM
Estimate against measurement, compound 4: 3.2-fold (0.51 log units) above, outside the stated range (below it).
By their numbers in this assay, from the lowest: compounds 4, 3 and 1 (each within the scatter of the next); then compound 2.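

In this assay, for the compounds shown here, methoxy in place of (trifluoromethyl)sulfanyl on this aromatic carbon gives a 1.4-fold lower number from compound 3 to compound 4 (0.14 log units; within the scatter), the first direct reading of a change at this position. On this core, then, the read-out does not separate the 4-((trifluoromethyl)sulfanyl)phenyl and 4-methoxyphenyl groups, although the two differ in size and atoms. Nothing measured here explains why they read alike. As far as these compounds go, whether an amine or a carboxylic acid at the same place would also read alike remains open. So does whether this exchange behaves the same way on a different core.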